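A few compounds are considered here, and "the series" means these few. Any claim that something is new, unique, unknown or untested is made for them only; others in the source may bear on it.

Measured compounds:
- Compound 2, `Cc1ccc(C(=O)NNC(=O)Cn2c(=O)c(Cc3ccccc3)nc3ccccc32)cc1`: in an assay for inhibition of Amine oxidase [flavin-containing] A (Bos taurus), read by fluorescence, with a stated time of 60 min (on this read-out lower numbers stand for stronger inhibition and higher numbers for weaker inhibition), compound 2 gives 52 nM.
- Compound 1, `O=C(NNc1nc2ccccc2nc1Cc1ccccc1)c1ccc(Br)cc1`: in this assay compound 1 gives 74 nM.

Compound 2 holds the lowest of these two numbers, but compound 1 sits so close that the two values lie within the usual scatter of each other, so neither can be called the stronger inhibitor on this evidence. The two compounds also differ in several places at once, so their pair gives no clean lesson about any single group.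

Compound 3, `O=C(Cn1c(=O)c(Cc2ccccc2)nc2ccccc21)NNC(=O)c1ccc(Cl)cc1`, is the next compound, and it differs from compound 2 in one place only: chloro in place of methyl on an aromatic carbon. Each of the two groups is a single heavy atom without a ring, and the swap brings no hydrogen-bond donor, no acceptor and no charge, leaving the shared core and the rest of the molecule untouched. Among the compounds with values here, no measured pair in this set shows a change of this kind, so there is no measured step to lean on. With so small a swap, the expectation is a step of no more than the scatter, in either direction.

Compound 3 is therefore expected to give about 50 nM, with a likely range from 20 nM to 130 nM. That estimate means an expected step of a 1.0-fold lower number from compound 2 to compound 3 (0.02 log units; within the scatter), which stays within the scatter.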

Compound 3, half-maximal inhibitory concentration: 64 nM
Compound 3: middle estimate off by 1.3-fold (0.11 log units), on the low side; the range from low to high includes it.
By their numbers in this assay, from the lowest: compounds 2, 3 and 1 (each within the scatter of the next).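

Within the data shown here, compound 2 and compound 3 form the first pair here that differs in one place only, so this change can be read on its own. In this assay, chloro in place of methyl on the aromatic carbon para to a large group gives a small step (a 1.2-fold higher number from compound 2 to compound 3 (0.09 log units; within the scatter)), and the two compounds cannot be told apart. At this position, then, a 4-chlorophenyl serves as well as a 4-methylphenyl on this read-out, and the match gives no sign that either group matters more than the other, though no available evidence bears on why the two groups read alike.

Methyl and chloro are both a single heavy atom without a ring, with no hydrogen-bond donors or acceptors and no net charge, so the pair tests only a narrow change and leaves open how this position would respond to an amine, a carboxylic acid or a longer chain. Going by these compounds, it is also open whether the same swap would read the same way on the core of compound 1, which differs from compound 2 and compound 3 in several places at once.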